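Ether to Sulfanyl Link on the Shared Core

The source may report more compounds than this note shows. Statements on the series, on what has been measured and on what is new or still open speak of the compounds shown alone.

Compound 1 `Nc1cc(N)c2nc(-c3ccccc3)c(Oc3ccc(Cl)c(Cl)c3)nc2c1`: 12000 nM
Compound 2 `CCOC(=O)[C@H](CCC(=O)O)NC(=O)c1ccc(Oc2nc3cc(N)cc(N)c3nc2-c2ccccc2)cc1`: < 100000 nM (a limit)

In a functional assay on U-251 cells (Homo sapiens) for inhibition, read by sulforhodamine B assay, with a stated time of 48 h (on this read-out lower numbers stand for stronger inhibition of growth and higher numbers for weaker inhibition of growth), compound 1 gives 12000 nM. Compound 2 sits at the limit of < 100000 nM in this assay, at which 1 of the 2 values shown sits. Going by the values given here, compound 1 therefore holds the only number given; the second entry is a limit and not a number, so no measured step between two compounds of this set is available to guide the next one.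

Compound 3 `Nc1cc(N)c2nc(-c3ccccc3)c(Sc3ccc(F)cc3)nc2c1` keeps the core of compound 1 and differs from it by (4-fluorophenyl)sulfanyl in place of 3,4-dichlorophenoxy on an aromatic carbon. Among the compounds with values here, with no measured step to lean on, only the size of this change can be weighed: the ring and its linking atom are exchanged, and two chlorines give way to one fluorine. The step from compound 1 to compound 3 is expected to be a 1.3-fold higher number from compound 1 to compound 3 (0.12 log units; within the scatter), that is, a small shift that may not exceed the scatter. Compound 3 is estimated at 16000 nM, with a range from 4000 nM to 60000 nM.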

Compound 3, concentration for 50% growth inhibition: 16200 nM
The estimate for compound 3 lay 1.0-fold (0.01 log units) below the measured number; the measured number falls inside the stated range.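

In this assay, this position on an aromatic carbon next to the ring nitrogen now gives its first readable step: a 1.4-fold higher number from compound 1 to compound 3 (0.13 log units; within the scatter). The exchange of 3,4-dichlorophenoxy for (4-fluorophenyl)sulfanyl replaces the linking atom and the halogens together, yet the two compounds cannot be told apart on this read-out, so this position tolerates that particular swap without a measurable change in growth inhibition. Nothing measured here accounts for this step.

The compounds shown leave open what the linking atom and the halogens each do alone, as a single pair changes both at once. Also open, going by these compounds, is whether a group of another kind at this position, such as piperidine or a short alkyl chain in place of the aryl ring, would move the number beyond the scatter.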